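The compounds below may be only part of what the source reports. "The series", "measured", "known", "first", "only" and "open" are said of these compounds alone.

Measured so far in a functional assay on Huh-7 cells (Homo sapiens) for inhibition, read by sulforhodamine B assay, with a stated time of 72 h; a lower number here means a stronger inhibitor, a higher number a weaker inhibitor

- Compound 1 `COC1=CC(=O)C(C)=C([S@@+]([O-])c2ccc(C)cc2)C1=O` gives 8000 nM
- Compound 2 `CCOC1=CC(=O)C(C)=C([S@@+]([O-])c2ccc(C)cc2)C1=O` gives 7000 nM
- Compound 3 `Cc1ccc([S@+]([O-])C2=C(Cl)C(=O)C=CC2=O)cc1` gives "not active" (no number reported)

Among the compounds with values here, compound 1 has only one neighbour with a number, compound 2, and the two cannot be told apart: the step is a 1.1-fold lower number from compound 1 to compound 2 (0.06 log units; within the scatter) and so gives no real difference. Compound 3 was reported without a number, so it cannot be placed on this scale.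

Compound 4 `COC1=CC(=O)C(C)=C([S+]([O-])c2ccc(C)cc2)C1=O` has not yet been measured in this assay and its link to compound 1 is simple: the two compounds have the same atoms and bonds; at least one stereo element is drawn with a configuration in one of them and without one in the other: 1 of 1 stereo elements differ; a stereocentre at a sulfur is drawn S in compound 1 and without a configuration in compound 4. Within the data shown here, no measured pair tests a change at this stereocentre. Among the measured compounds shown here, the only step available, a 1.1-fold lower number from compound 1 to compound 2 (0.06 log units; within the scatter), comes from a different change, a methyl in place of hydrogen on a saturated chain carbon, so it offers only indirect guidance. No shift beyond the scatter is therefore expected, and the estimated step is no change at the digits printed from compound 1 to compound 4 (within the scatter) in this assay. For compound 4 the estimate is 8000 nM with an expected range from 4000 nM to 16000 nM.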

Compound 4, half-maximal inhibitory concentration: 5500 nM
Estimate against measurement, compound 4: 1.5-fold (0.16 log units) above; low and high end bracket the measured number.
By their numbers in this assay, from the lowest: compounds 4, 2 and 1 (each within the scatter of the next).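

The earlier pair tested only the chain on the oxygen, whereas this pair bears on the stereocentre at sulfur. In this assay, the step is a 1.5-fold lower number from compound 1 to compound 4 (0.16 log units; within the scatter), so the two compounds cannot be told apart, and leaving the configuration at sulfur undrawn gives no real difference from the S drawing. The comparison rests on a single difference in how the structures are drawn: the fact that one of compounds 1 and 4 is drawn with a defined configuration and the other without, at the place where they differ

A drawing without a configuration does not say whether compound 4 is one form or a mixture, so the effect of the sulfur configuration remains unresolved, and a compound drawn with the opposite configuration would be needed to settle it. Also open, on these data alone, is whether a longer chain on the oxygen, or an amine in place of that oxygen, would shift the number beyond the scatter.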